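The source may hold more compounds than are shown below. What is called first, only, known or untested is meant among the compounds shown, and "the series" means these compounds.

Measured compounds:
Compound 1, `Nc1cc(-c2ccccc2)nc2ccc(NC(=O)/C=C/c3ccc(C(F)(F)F)cc3)cc12`: 18.5 nM
Compound 2, `CCCc1cc(N)c2cc(NC(=O)C3CCC(c4ccc(Cl)cc4)CC3)ccc2n1`: 4.4 nM
Compound 3, `CCCc1cc(N)c2cc(NC(=O)c3ccc(C(F)(F)F)cc3)ccc2n1`: 10000 nM

Of the compounds shown here, three have been measured in an assay on isolated protein for displacement of a labelled ligand from melanin-concentrating hormone receptor 1 (Homo sapiens); a lower number here means a stronger inhibitor, a higher number a weaker inhibitor. Compound 1 stands second of the three: compound 2 gives a lower number, a gap beyond the usual scatter, while compound 3 gives a far higher number, also well beyond the scatter. Compounds 2 and 3 share the same core with a propyl group where compound 1 carries a phenyl, and differ from each other only in the amide part, so the numbers show that an alkyl group at that position is compatible with a low value in this assay when the amide part is suitable.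

Compound 4, `Nc1cc(C2CCCC2)nc2ccc(NC(=O)/C=C/c3ccc(C(F)(F)F)cc3)cc12`, is not yet measured. It differs from compound 1 in one place: cyclopentyl in place of phenyl on an aromatic carbon. The amide part of compound 1 is kept unchanged. Among the measured compounds shown here, no measured pair shows this particular change, so the expectation rests on compound 2, whose value of 4.4 nM shows that a non-aromatic group at this position can give a strong result. Compound 4 is therefore expected to stay near compound 1, with a step of a 1.4-fold higher number from compound 1 to compound 4 (0.13 log units; within the scatter) that may lie within the scatter or be a small loss. The estimate for compound 4 is 25 nM, in the range 8 nM to 80 nM.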

Compound 4, half-maximal inhibitory concentration: 0.8 nM
The estimate for compound 4 lay 31-fold (1.49 log units) above the measured number; measured number outside the range, below it.
By their numbers in this assay, from the lowest: compound 4; then compound 2; then compound 1; then compound 3.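

With the amide part held unchanged, cyclopentyl in place of phenyl on the aromatic carbon next to the ring nitrogen gives a 23-fold lower number from compound 1 to compound 4 (1.36 log units; beyond the scatter) in this assay. Among the compounds shown here, the earlier compounds showed only that a propyl group could accompany a low number with a different amide part; this pair isolates the group at this position and shows that the result depends strongly on it. With this amide part, an aromatic ring is not needed here, and a five-membered non-aromatic carbon ring gives the lowest number of the series, with compound 4 at 0.8 nM. Nothing available explains why this one exchange has so large an effect.

The compounds shown leave open whether the gain is particular to cyclopentyl or extends to other groups at this position, such as cyclohexyl, a longer chain or an amine. They also leave open whether propyl would do as well as cyclopentyl alongside the amide part of compound 1, and whether cyclopentyl would give a similar gain with the amide parts of compound 2 or compound 3.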